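The source may hold more compounds than are shown below. What is called first, only, known or untested is meant among the compounds shown, and "the series" means these compounds.

For the measured compounds named here, compound 3 `COc1cc(OC)c2c(=O)cc(-c3ccc(OCCN4CCCC4=O)cc3)oc2c1` gives the highest of the three numbers measured so far: in a functional assay (Homo sapiens) for antiproliferative activity, read by resazurin assay, with a stated time of 48 h, tested at 20 uM (a higher number here means a stronger effect of the compound at the concentration tested, a lower number a weaker effect), compound 3 gives 33%. Compound 1 `COc1cc(OC)c2c(=O)cc(-c3ccc(OCCBr)cc3)oc2c1` gives 20% in this assay, and compound 2 `COc1cc(OC)c2c(=O)cc(-c3ccc(OCCF)cc3)oc2c1` gives 21%. Both steps toward compound 3 lie beyond the scatter: a number 13 percentage points higher from compound 1 to compound 3 (beyond the scatter) and a number 12 percentage points higher from compound 2 to compound 3 (beyond the scatter), while a number 1 percentage points higher from compound 1 to compound 2 (within the scatter).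

Compound 4 `COc1cc(OC)c2c(=O)cc(-c3ccc(OCC(O)CN4CCCC4)cc3)oc2c1` differs from compound 3 in one place: 1-hydroxy-2-(pyrrolidin-1-yl)ethyl in place of (2-oxopyrrolidin-1-yl)methyl on a saturated chain carbon bound to an oxygen on an aromatic ring. Going by the values given here, none of the measured steps makes this exact change; the two that bear on it, from compound 1 and from compound 2 to compound 3, both put the 2-oxopyrrolidin-1-yl group in place of a halogen and brought modest gains. In compound 4 that group leaves and a 1-hydroxy-2-(pyrrolidin-1-yl)ethyl group enters. Those steps therefore give only a loose guide, and no step beyond the scatter is expected in either direction. For compound 4 in this assay the estimate is 35%, ranging from 18% to 55%, which corresponds to an expected step of a number 2 percentage points higher from compound 3 to compound 4 (within the scatter).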

Compound 4, a percentage reported as inhibition, at one concentration (the size of the read-out at that concentration, not a potency): 57%
For compound 4 the middle estimate is 22 percentage points below the measured one, outside the stated range (above it).
By their numbers in this assay, from the lowest: compounds 1 and 2 (each within the scatter of the next); then compound 3; then compound 4.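

In this assay, for the compounds shown here, the place on a saturated chain carbon bound to an oxygen on an aromatic ring proves able to carry a much higher read-out than the earlier compounds showed: 1-hydroxy-2-(pyrrolidin-1-yl)ethyl in place of (2-oxopyrrolidin-1-yl)methyl gives a number 24 percentage points higher from compound 3 to compound 4 (beyond the scatter) for this change. Set against the halogen compounds, the same group gives a number 36 percentage points higher from compound 2 to compound 4 (beyond the scatter) and a number 37 percentage points higher from compound 1 to compound 4 (beyond the scatter) as large steps, where the 2-oxopyrrolidin-1-yl group had brought only modest ones. No measurement shown here accounts for this gain.

The change alters the ring, the chain and the hydroxyl at once, so the compounds shown do not separate their contributions. A 3-(pyrrolidin-1-yl)propoxy chain without the hydroxyl, or a 2-hydroxy-3-(piperidin-1-yl)propoxy chain, would bear on that question.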